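The source may hold more compounds than are shown below. What is called first, only, known or untested is meant among the compounds shown, and "the series" means these compounds.

Measured so far:
Compound 1, `COc1cc(/C=C/C(=O)Nc2ccccc2)ccc1O`: 1.42 in a physicochemical assay for lipophilicity, using the shake flask method, measured as octanol-water partition, at pH 7.4; on this read-out lower numbers stand for lower lipophilicity and higher numbers for higher lipophilicity
Compound 2, `COc1cc(/C=C/C(=O)Nc2ccccc2)ccc1OCCCCCN1CCCC1`: 1.64 in this assay

Going by the values given here, compound 2 gives the highest of the two numbers so far, but its nearest neighbour, compound 1, sits only a number 0.22 log units higher from compound 1 to compound 2 (within the scatter) away, a gap within the scatter. The next compound, compound 3, is `COc1cc(/C=C/C(=O)Nc2ccccc2)ccc1OCCCCCCCCCCN1CCCCC1`. It differs from compound 2 in one place: 5-(piperidin-1-yl)pentyl in place of pyrrolidin-1-yl on a saturated chain carbon, five bonds along the chain from an oxygen on an aromatic ring. Among the compounds with values here, only one measured step bears on this change, the one from compound 1 to compound 2, which attached the whole chain and ring to the aromatic oxygen and moved the number a number 0.22 log units higher from compound 1 to compound 2 (within the scatter). Within the data shown here, the new step lengthens the chain by the counts given and enlarges the ring, so a rise in this assay beyond the scatter is expected, although no measured pair shows a change of this size directly. For compound 3 the estimate is 2.7, within a range from 1.9 to 3.5, which means an expected step of a number 1.06 log units higher from compound 2 to compound 3 (beyond the scatter).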

Compound 3, partition coefficient: 1.83
The estimate for compound 3 lay 0.87 log units above the measured number; measured number outside the range, below it.
By their numbers in this assay, from the lowest: compounds 1, 2 and 3 (each within the scatter of the next, the first and the last beyond it).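

In this assay, putting 5-(piperidin-1-yl)pentyl in place of pyrrolidin-1-yl, on a saturated chain carbon five bonds along the chain from an oxygen on an aromatic ring, gives a number 0.19 log units higher from compound 2 to compound 3 (within the scatter), so the read-out does not separate these two compounds, although the entering group has 11 heavy atoms and the leaving group 5. The earlier pair could not show this, since it covered only the attachment of the first chain and ring to the oxygen. Nothing measured here offers a reason for this result.

Still open, on these data alone, is how the two parts of this change count separately, which a longer chain ending in pyrrolidin-1-yl would help to show. Also open, as far as these compounds go, is whether another end group, such as a carboxylic acid or a morpholine ring, would stand beyond the scatter of compound 2.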